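Three Anilides Below Detection for Thiosulfate Sulfurtransferase Inhibition

The source may hold more compounds than are shown below. What is called first, only, known or untested is meant among the compounds shown, and "the series" means these compounds.

Compound 1 `O=C(Nc1cccc(Cl)c1)c1cc(Br)cc(Br)c1O`, compound 2 `O=C(Nc1cccc(Cl)c1)c1cc(Br)cc(Br)c1` and compound 3 `O=C(Nc1cccc(Cl)c1)c1cccc(Br)c1` share an anilide core and were examined in an assay on isolated protein for inhibition of thiosulfate sulfurtransferase (Homo sapiens), with a stated time of 60 min, in the absence of a further agent; on this read-out higher numbers stand for weaker inhibition and lower numbers for stronger inhibition. In this assay compound 1 gives only the assay limit > 100000 nM. In this assay compound 2 likewise reaches only the limit > 100000 nM. In this assay compound 3 also returns the limit > 100000 nM. The change hydroxy in place of hydrogen on an aromatic carbon thus yields a step that the two limits leave unreadable from compound 2 to compound 1, and the core change hydrogen in place of bromo on an aromatic carbon yields a step that the two limits leave unreadable from compound 2 to compound 3, both resting on (the limit of > 100000 nM in this assay, at which 3 of the 3 values shown sit).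

Compound 4 `O=C(Nc1cccc(Cl)c1)c1cc(Br)ccc1O` is not yet measured; it differs from compound 3 by hydroxy in place of hydrogen on an aromatic carbon, the same kind of change as from compound 2 to compound 1, though there the place was also ortho to a bromo group. With no readable step anywhere, the step from compound 3 to compound 4 is estimated as a step that the limit leaves unreadable from compound 3 to compound 4, resting on compound 3 itself. Compound 4 is expected at 150000 nM, between 60000 nM and 400000 nM.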

Compound 4, half-maximal inhibitory concentration: > 100000 nM
Compound 4 was reported as a limit; the forecaster's own chance of this, stated with the estimate: 85%; the middle value is on the limit's open side.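

No step can be read from compound 3 to compound 4 or from compound 1 to compound 4, because both ends of each pair sit at one limit: the limit of > 100000 nM in this assay, at which 4 of the 4 values shown sit.

As far as these compounds go, whether hydroxy or bromo on the shared core alters inhibition at all stays open in this assay.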